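This account rests on a few compounds, and the source may have more. Where it says the series, first, only, none or still open, it means among the compounds named here.

Measured so far in an ADME assay on cells (Hepatocyte, Mus musculus) for metabolic stability; a lower number here means that the compound disappears faster, a higher number that the compound lasts longer:
- compound 1 `O=C(OC1CCC(CN2CCN(c3cc(=O)c4cc(C(F)(F)F)cc([N+](=O)[O-])c4s3)CC2)CC1)c1ccncc1`: 0.0817 h
- compound 2 `O=C(OC1CCC(CN2CCN(c3cc(=O)c4cc(C(F)(F)F)cc([N+](=O)[O-])c4s3)CC2)CC1)C1CCCCC1`: 0.0783 h

Going by the values given here, compound 2, at 0.0783 h, does not stand apart from the only other measured compound. Among the compounds with values here, the single step available is a 1.0-fold lower number from compound 1 to compound 2 (0.02 log units; within the scatter), with cyclohexyl in place of pyridin-4-yl on a carbonyl carbon.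

Next is compound 3 `CC(=O)NC1CCC(CN2CCN(c3cc(=O)c4cc(C(F)(F)F)cc([N+](=O)[O-])c4s3)CC2)CC1`, not yet measured. The structural change is acetamido in place of (cyclohexylcarbonyl)oxy on a saturated ring carbon.

The measured step bears on this only in part. Within the data shown here, it altered what sits on the carbonyl carbon, whereas compound 3 loses the whole (cyclohexylcarbonyl)oxy group, and no measured pair tests that replacement. The step's small size therefore sets no firm expectation, and the uncertainty is wide. A higher number than that of compound 2 is expected, probably beyond the scatter, though no change remains possible. The expected step is a 3.8-fold higher number from compound 2 to compound 3 (0.58 log units; beyond the scatter). The estimated half-life for compound 3 is 0.3 h, with an expected range of 0.08 h to 1.2 h.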

Compound 3, half-life: > 1.55 h
Compound 3 gave a limit, no number (the forecaster's own chance of this, stated with the estimate: 5%); middle value at least 5.1-fold (0.71 log units) from the limit.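

In this assay, the saturated ring carbon of the six-membered carbon ring proves sensitive to a change of the whole group, with acetamido in place of (cyclohexylcarbonyl)oxy giving an at least 19-fold higher number from compound 2 to compound 3 (1.29 log units; beyond the scatter), and acetamido in place of ((pyridin-4-yl)carbonyl)oxy giving an at least 18-fold higher number from compound 1 to compound 3 (1.27 log units; beyond the scatter). Both steps are large and beyond the scatter, whereas the change on the carbonyl carbon alone, a 1.0-fold lower number from compound 1 to compound 2 (0.02 log units; within the scatter), lay within it, so the earlier pair gave no sign of how much this position could move the half-life. Compound 3 stands at a limit of the assay and not at a number, which leaves the full size of both steps open: the limit of > 1.55 h in this assay, at which 1 of the 3 values shown sits.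

The compounds shown do not separate the departure of the ester-type groups from the arrival of acetamido, or either of these from the smaller heavy-atom count of the entering group. A hydroxyl group, a primary amine or a longer amide chain such as propanamido on the same ring carbon would address that question.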